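Replacing Benzylsulfanyl with Dimethoxyphenyl on the Aromatic Carbon

The source may report more compounds than this note shows. Statements on the series, on what has been measured and on what is new or still open speak of the compounds shown alone.

Three measured compounds share one core and differ only in the group on one aromatic carbon. Compound 1 `CC(C(=O)NCc1ccc(C(F)(F)F)cc1N1CCCCCC1)c1ccc(NS(C)(=O)=O)c(F)c1` gives 1.6 nM in an assay on CHO cells for antagonist activity at transient receptor potential cation channel subfamily V member 1 (Homo sapiens), read by FLIPR; on this read-out higher numbers stand for weaker inhibition and lower numbers for stronger inhibition. Compound 2 `CC(C)CCOc1cc(C(F)(F)F)ccc1CNC(=O)C(C)c1ccc(NS(C)(=O)=O)c(F)c1` gives 0.5 nM, and compound 3 `CC(C(=O)NCc1ccc(C(F)(F)F)cc1SCc1ccccc1)c1ccc(NS(C)(=O)=O)c(F)c1` gives 0.5 nM. Compound 3 thus stands level with compound 2, the two sharing the lowest numbers of three, as no change at the digits printed from compound 2 to compound 3 (within the scatter); compound 1 is furthest away, shown by a 3.2-fold lower number from compound 1 to compound 3 (0.51 log units; beyond the scatter) and likewise a 3.2-fold lower number from compound 1 to compound 2 (0.51 log units; beyond the scatter). Compound 4 `COc1cc(OC)cc(-c2cc(C(F)(F)F)ccc2CNC(=O)C(C)c2ccc(NS(C)(=O)=O)c(F)c2)c1` carries the change (3,5-dimethoxyphenyl in place of benzylsulfanyl on an aromatic carbon). Among the compounds with values here, every step at this position so far was modest or within the scatter, so the step of a 2.0-fold higher number from compound 3 to compound 4 (0.30 log units; within the scatter) in this assay is expected to be small, if anything toward a higher number. Compound 4 is therefore estimated at 1 nM, with a range of 0.3 nM to 4 nM.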

Compound 4, inhibition constant: 5.8 nM
Beside the measured number, compound 4's estimate is 5.8-fold (0.76 log units) below it; measured number outside the range, above it.
By their numbers in this assay, from the lowest: compounds 2 and 3 (each within the scatter of the next); then compound 1; then compound 4.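

Within the data shown here, this position proves less tolerant than the earlier compounds suggested. In this assay, among these compounds, 3,5-dimethoxyphenyl brings the first large steps here, a 12-fold higher number from compound 3 to compound 4 (1.06 log units; beyond the scatter) and a 12-fold higher number from compound 2 to compound 4 (1.06 log units; beyond the scatter), and even against the azepan-1-yl group it gives a 3.6-fold higher number from compound 1 to compound 4 (0.56 log units; beyond the scatter). Benzylsulfanyl and isopentyloxy therefore share a low number that this group does not reach, so the earlier compounds had not shown how far the number can move at this carbon.

The compounds shown leave open whether the rise goes with the ring or with its two methoxy groups, which a plain phenyl group would help separate. Nothing available explains the rise.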